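Swapping a Carboxyphenyl Arm for a Fused Nitrogen Ring

A few compounds are considered here, and "the series" means these few. Any claim that something is new, unique, unknown or untested is made for them only; others in the source may bear on it.

Compound 1, `CCOC(=O)C1=C(Nc2ccccc2)S/C(=C\c2ccc(C(=O)O)cc2)C1=O`: < 10%
Compound 2, `CCOC(=O)C1=C(Nc2cccc(C(F)(F)F)c2)S/C(=C\c2ccc[nH]2)C1=O`: 22.9%

Of the compounds shown here, two have been tested so far in a functional assay on MCF7 cells (Homo sapiens) for inhibition, read by MTT assay, with a stated time of 72 h, tested at 10 uM; on this read-out lower numbers stand for less inhibition and higher numbers for more inhibition at the one concentration tested (going by the name of the read-out). Compound 1 sits at the limit of < 10%, which is a limit of the assay and not a number. Differing from compound 1 at two places of the shared core, compound 2 gives 22.9% in this assay. Among the compounds with values here, because no single-site step connects them, their values show only that compound 2 stands above the limit at which compound 1 sits (the limit of < 10% in this assay, at which 1 of the 2 values shown sits).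

Compound 3, `CCOC(=O)C1=C(Nc2ccccc2)S/C(=C\c2cc3cccnc3[nH]2)C1=O`, keeps the part of compound 1 bound to the amine nitrogen and changes the other arm: a group of 9 heavy atoms (7 carbon, 2 nitrogen; one five-membered aromatic ring with 1 hetero atom, one six-membered aromatic ring with 1 hetero atom) in place of a group of 9 heavy atoms (7 carbon, 2 oxygen; one six-membered aromatic ring of carbon only), on a double-bonded chain carbon bound to a double-bonded ring carbon. Within the data shown here, with no measured single-site step, the expected size is uncertain. Since compound 2 gives 22.9% with a five-membered aromatic ring at that place, a modest rise in this assay is expected, a number at least 10 percentage points higher from compound 1 to compound 3 (that floor lies within the scatter), though it may stay within the scatter. Compound 3 is therefore estimated at 20%, with a range from 5% to 40%.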

Compound 3, a percentage reported as inhibition, at one concentration (the size of the read-out at that concentration, not a potency): 18.2%
Compound 3: middle estimate off by 1.8 percentage points, on the high side; low and high end bracket the measured number.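

In this assay, replacing the 4-carboxyphenyl arm with the group carrying a five-membered and a six-membered aromatic ring, while the part on the amine nitrogen stays the same, gives a number at least 8.2 percentage points higher from compound 1 to compound 3 (that floor lies within the scatter). For compound 1, the value < 10% is a limit of the assay and not a number. The step is known only as a floor, and its true size cannot be read, because one end of it rests on that limit: the limit of < 10% in this assay, at which 1 of the 3 values shown sits.

The compounds shown leave open whether the result depends on losing the carboxylic acid or on gaining the new ring group, which a plain phenyl at this place could help separate. They also leave open how an amine on that phenyl would behave.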